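Lengthening the Side-Chain Amine on the Shared Core

The source may hold more compounds than are shown below. What is called first, only, known or untested is meant among the compounds shown, and "the series" means these compounds.

Of the compounds shown here, three sharing one core have been measured in an assay on isolated protein for inhibition of DNA topoisomerase 1 (Homo sapiens), with a stated time of 15 min; on this read-out higher numbers stand for weaker inhibition and lower numbers for stronger inhibition. Compound 1 `O=C(O)c1cn(Cc2ccc(-c3ccccc3)cc2)c2cc(N3CC4CNCC4C3)c(F)cc2c1=O` gives 33300 nM. Compound 2 `O=C(O)c1cn(Cc2ccc(-c3ccccc3)cc2)c2cc(NC[C@@H]3CCNC3)c(F)cc2c1=O` gives 104000 nM, and compound 3 `NCCNc1cc2c(cc1F)c(=O)c(C(=O)O)cn2Cc1ccc(-c2ccccc2)cc1` gives 72800 nM. Compound 3 therefore stands second highest of the three numbers: the step of a 2.2-fold higher number from compound 1 to compound 3 (0.34 log units; beyond the scatter) is beyond the scatter, while the step of a 1.4-fold lower number from compound 2 to compound 3 (0.15 log units; within the scatter) lies within it.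

Compound 4 `CNCCCNc1cc2c(cc1F)c(=O)c(C(=O)O)cn2Cc1ccc(-c2ccccc2)cc1` differs from compound 3 by (methylamino)methyl in place of amino on a saturated chain carbon, two bonds along the chain from a nitrogen on an aromatic ring. The step that bears most directly on this change is a 1.4-fold lower number from compound 2 to compound 3 (0.15 log units; within the scatter), where exchanging one chain-borne amine for another left the number within the scatter. The step of a 2.2-fold higher number from compound 1 to compound 3 (0.34 log units; beyond the scatter) shows a modest loss when the two fused rings gave way to an open chain, but compound 4 keeps the open chain. Compound 4 is therefore expected to move by a 1.0-fold lower number from compound 3 to compound 4 (0.02 log units; within the scatter), a step not beyond the scatter. In this assay compound 4 is estimated to give 70000 nM, with a range from 30000 nM to 180000 nM.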

Compound 4, half-maximal inhibitory concentration: 63600 nM
Estimate against measurement, compound 4: 1.1-fold (0.04 log units) above, and the stated range covers the measured number.
By their numbers in this assay, from the lowest: compounds 1, 4, 3 and 2 (each within the scatter of the next, the first and the last beyond it).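

In this assay, (methylamino)methyl in place of amino on a saturated chain carbon, two bonds along the chain from a nitrogen on an aromatic ring, shows that this open chain can be extended and its amine methylated without a change beyond the scatter: a 1.1-fold lower number from compound 3 to compound 4 (0.06 log units; within the scatter). The extended chain also stays within the scatter of both ring-bearing side chains, with a 1.6-fold lower number from compound 2 to compound 4 (0.21 log units; within the scatter) and a 1.9-fold higher number from compound 1 to compound 4 (0.28 log units; within the scatter), whereas the shorter chain gave a 2.2-fold higher number from compound 1 to compound 3 (0.34 log units; beyond the scatter). No evidence here accounts for these numbers.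

The compounds shown leave open whether a longer chain would stay within the scatter of these values. They also leave open how a dimethylamino group at the chain end, or a hydroxyl group in place of its amine, would read in this assay.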